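Methyl for methoxy on an aryl piperazine thiocarbamate

This account rests on a few compounds, and the source may have more. Where it says the series, first, only, none or still open, it means among the compounds named here.

Measured so far:
compound 1, `Nc1ccccc1NC(=O)c1ccc(CSC(=S)N2CCN(C(c3ccccc3)c3ccccc3)CC2)cc1`: 8.4%
compound 2, `COc1ccc(N2CCN(C(=S)SCc3ccc(C(=O)Nc4ccccc4N)cc3)CC2)cc1`: 35.9%
compound 3, `Nc1ccccc1NC(=O)c1ccc(CSC(=S)N2CCCC2)cc1`: 89.5%

In a functional assay on A-375 cells (Homo sapiens) for antiproliferative activity, read by CCK-8 assay, with a stated time of 72 h, tested at 8 uM (on this read-out lower numbers stand for a weaker effect and higher numbers for a stronger effect at the one concentration tested), compound 2 gives 35.9%, the second highest of the three numbers. Its nearest neighbour, compound 1, gives 8.4%, a lower number beyond the usual scatter, while compound 3 gives 89.5%, the highest of the three and again beyond the scatter. Compound 4 `Cc1ccc(N2CCN(C(=S)SCc3ccc(C(=O)Nc4ccccc4N)cc3)CC2)cc1` has not yet been measured. It differs from compound 2 in one place: methyl in place of methoxy on an aromatic carbon. Among the measured compounds shown here, no pair of measured compounds shows this same change, so the expectation rests on the change itself. The step of a number 2.1 percentage points higher from compound 2 to compound 4 (within the scatter) is expected to be small, in either direction, and likely within the scatter. Compound 4 is therefore estimated at 38%, with a range from 18% to 60%.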

Compound 4, a percentage reported as inhibition, at one concentration (the size of the read-out at that concentration, not a potency): 26.4%
For compound 4 the middle estimate is 11.6 percentage points above the measured one; measured number inside the range.
By their numbers in this assay, from the lowest: compound 1; then compounds 4 and 2 (each within the scatter of the next); then compound 3.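

The change from 4-methoxyphenyl to 4-methylphenyl reads as a number 9.5 percentage points lower from compound 2 to compound 4 (within the scatter) in this assay. Among the compounds shown here, on this aromatic carbon, para to a large group, the oxygen and its hydrogen-bond acceptor can therefore be lost with no effect separable from scatter, something the earlier compounds, which differ in more than one place, could not show. Going by these compounds, whether an amine or a carboxylic acid at this position would move the number beyond the scatter remains open. Nothing available gives a reason for this result.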